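A few compounds are considered here, and "the series" means these few. Any claim that something is new, unique, unknown or untested is made for them only; others in the source may bear on it.

In a functional assay on BXPC-3 cells (Homo sapiens) for cytotoxicity, read by MTT assay, with a stated time of 72 h (a higher number here means a weaker inhibitor, a lower number a stronger inhibitor), compound 3 `O=C(c1ccc(F)cc1)c1cccc(/C=c2\[nH]c(=O)/c(=C/c3nc[nH]c3C3CC3)[nH]c2=O)c1` gives 1.4 nM, the lowest number of the set, compared with compound 1 `CC(C)c1[nH]cnc1/C=c1\[nH]c(=O)/c(=C/c2cccc(Oc3ccc(F)cc3)c2)[nH]c1=O` at 3.4 nM and compound 2 `O=c1[nH]/c(=C\c2nc[nH]c2C2CC2)c(=O)[nH]/c1=C\c1cccc(Oc2ccc(F)cc2)c1` at 9.4 nM. Compound 4 `COCc1ccc(/C=c2\[nH]c(=O)/c(=C/c3cccc(C(=O)c4ccc(F)cc4)c3)[nH]c2=O)o1` has 5-(methoxymethyl)furan-2-yl in place of 5-cyclopropyl-1H-imidazol-4-yl on a double-bonded chain carbon bound to an aromatic carbon. Two measured steps offer only indirect guidance. Exchanging isopropyl for cyclopropyl gave a 2.8-fold higher number from compound 1 to compound 2 (0.44 log units; beyond the scatter), and changing the group at the other end gave a 6.7-fold lower number from compound 2 to compound 3 (0.83 log units; beyond the scatter). Among the compounds with values here, neither step replaces the whole 5-cyclopropyl-1H-imidazol-4-yl group, so the data contain no direct precedent. A step to a higher number, somewhat larger than both of these, is therefore expected, though with wide uncertainty. The expected change is a 14-fold higher number from compound 3 to compound 4 (1.15 log units; beyond the scatter). The estimate for compound 4 is 20 nM, within an expected range of 4 nM to 100 nM.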

Compound 4, half-maximal inhibitory concentration: 2 nM
For compound 4 the middle estimate is 10-fold (1.00 log units) above the measured one, and the stated range ends above it.
By their numbers in this assay, from the lowest: compounds 3, 4 and 1 (each within the scatter of the next, the first and the last beyond it); then compound 2.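

In this assay, 5-(methoxymethyl)furan-2-yl in place of 5-cyclopropyl-1H-imidazol-4-yl gives a 1.4-fold higher number from compound 3 to compound 4 (0.15 log units; within the scatter), so this position accepts the exchange of a whole group, not just of the small substituent changed earlier. The entering group has no hydrogen-bond donor and the leaving group has one, so in this pair that donor is not required for a low number. Nothing measured here explains why the two groups match.

Still open, as far as these compounds go, is whether an amine or a carboxylic acid in place of the methoxymethyl group would keep the number this low. Also open, from the compounds shown here alone, is whether ethoxymethyl, a longer chain, would do the same.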